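This account rests on a few compounds, and the source may have more. Where it says the series, first, only, none or still open, it means among the compounds named here.

Measured so far in an ADME assay on MT4 cells (Homo sapiens) for cytotoxicity, read by MTT assay, with a stated time of 5 days; on this read-out higher numbers stand for lower toxicity in this test and lower numbers for higher toxicity in this test:
- compound 1 `COc1cc2nc([S+]([O-])CC(=O)Nc3cccc(Cl)c3)nc(Nc3c(Cl)cc(/C=C/C#N)cc3Cl)c2cc1OC` gives 68900 nM
- compound 2 `COc1cc2nc([S+]([O-])CC(=O)Nc3ccc(Cl)cc3)nc(Nc3c(Cl)cc(/C=C/C#N)cc3Cl)c2cc1OC` gives 14400 nM
- compound 3 `COc1cc2nc([S+]([O-])CC(=O)Nc3ccc(C(F)(F)F)cc3)nc(Nc3c(Cl)cc(/C=C/C#N)cc3Cl)c2cc1OC` gives 22000 nM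

Compound 3 stands second highest of these three numbers in this assay: towards compound 2 the gap is a 1.5-fold higher number from compound 2 to compound 3 (0.18 log units; within the scatter), and from compound 1 it reads a 3.1-fold lower number from compound 1 to compound 3 (0.50 log units; beyond the scatter). Compound 4 `COc1cccc(NC(=O)C[S+]([O-])c2nc(Nc3c(Cl)cc(/C=C/C#N)cc3Cl)c3cc(OC)c(OC)cc3n2)c1` has not been measured yet. It differs from compound 3 in one place: 3-methoxyphenyl in place of 4-(trifluoromethyl)phenyl on an amide-type nitrogen. Among the compounds with values here, two measured steps bear on this change. From compound 1, which carries 3-chlorophenyl, the steps ran a 4.8-fold lower number from compound 1 to compound 2 (0.68 log units; beyond the scatter) and a 3.1-fold lower number from compound 1 to compound 3 (0.50 log units; beyond the scatter), so the 3-chlorophenyl compound sat above compound 2 and compound 3 in this assay. Within the data shown here, the incoming 3-methoxyphenyl shares its name pattern with 3-chlorophenyl, yet methoxy is not chloro, and no methoxy compound has been measured, so the parallel is loose. A modest rise is therefore expected, roughly a 1.8-fold higher number from compound 3 to compound 4 (0.26 log units; within the scatter), though a number within the scatter of compound 3 would not surprise. Compound 4 is estimated at 40000 nM in this assay, with a range from 15000 nM to 110000 nM.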

Compound 4, half-maximal cytotoxic concentration: >= 167000 nM
Compound 4 was reported as a limit (the forecaster's own chance of this, stated with the estimate: 15%); middle value at least 4.1-fold (0.62 log units) from the limit.
By their numbers in this assay, from the lowest: compounds 2 and 3 (each within the scatter of the next); then compound 1. At a limit, above all of these: compound 4.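

In this assay, compound 4 is reported only as a limit: the limit of >= 167000 nM in this assay, at which 1 of the 4 values shown sits. Within the data shown here, with 3-methoxyphenyl on the amide-type nitrogen, the data show an at least 7.5-fold higher number from compound 3 to compound 4 (0.88 log units; beyond the scatter) and an at least 11-fold higher number from compound 2 to compound 4 (1.06 log units; beyond the scatter), so a change at this place can shift the number further than the earlier compounds showed. Methoxy in place of chloro on an aromatic carbon still gives an at least 2.4-fold higher number from compound 1 to compound 4 (0.38 log units; beyond the scatter), so the change of group itself matters here, and compound 1 does not mark the top of the series.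

The compounds shown leave open how 4-methoxyphenyl would read on this nitrogen, which would separate the methoxy group from its place on the ring. They also leave open whether a longer chain such as ethoxy, or an amine on the phenyl ring, would read like methoxy.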